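Iodo Against Hydrogen on the Aromatic Ring

The source may hold more compounds than are shown below. What is called first, only, known or untested is meant among the compounds shown, and "the series" means these compounds.

Compound 1 `CN1CCC/C1=N\C(=O)Nc1cccc(Cl)c1`: 15 mg/kg
Compound 2 `CN1CCC/C1=N\C(=O)Nc1ccccc1`: 15 mg/kg

In a functional assay on the whole organism with Rattus norvegicus as the target, with a stated time of 5 days (on this read-out higher numbers stand for an effect only at larger amounts of compound and lower numbers for an effect already at smaller amounts), compound 1 gives 15 mg/kg and compound 2 gives 15 mg/kg. Compound 2 stands level with compound 1 on these numbers; the step of no change at the digits printed from compound 1 to compound 2 (within the scatter) lies within the scatter. Compound 3 `CN1CCC/C1=N\C(=O)Nc1cccc(I)c1` differs from compound 2 by iodo in place of hydrogen on an aromatic carbon. For the measured compounds named here, the only measured step bearing on this is the one in which chloro gave way to hydrogen on an aromatic carbon, and it stayed within the scatter. Iodo in that place is therefore expected to bring no step beyond the scatter, no change at the digits printed from compound 2 to compound 3 (within the scatter). Compound 3 is expected to give 15 mg/kg, within 7 mg/kg to 30 mg/kg.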

Compound 3, minimum effective dose: > 25 mg/kg
Compound 3: only a limit was reported; the forecaster's own chance of this, stated with the estimate: 5%; middle value at least 1.6-fold (0.22 log units) from the limit.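

With iodo on an aromatic carbon meta to a large group, compound 3 is the only compound here to give a limit rather than a number in this assay: the limit of > 25 mg/kg in this assay, at which 1 of the 3 values shown sits.

Iodo in place of hydrogen gives an at least 1.6-fold higher number from compound 2 to compound 3 (0.22 log units; that floor lies within the scatter), and iodo in place of chloro gives an at least 1.6-fold higher number from compound 1 to compound 3 (0.22 log units; that floor lies within the scatter). Both floors lie within the scatter, so iodo is not yet set apart from hydrogen or chloro at this position.

As far as these compounds go, how far compound 3 actually lies from the other two stays open, and so does the reading for a methoxy group or an amine in this place.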